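The source may hold more compounds than are shown below. What is called first, only, known or untested is meant among the compounds shown, and "the series" means these compounds.

In a functional assay on MIA PaCa-2 cells (Homo sapiens) for inhibition, read by MTT assay, with a stated time of 3 days (on this read-out higher numbers stand for weaker inhibition and lower numbers for stronger inhibition), compound 1 `CCN(CC)S(=O)(=O)c1ccc(S(=O)(=O)N2CCC[C@@H](C(=O)N[C@H]3CC[C@H](OC)CC3)C2)cc1` gives > 10000 nM, which is a limit of the assay and not a measured number. Compound 2 `O=C([C@@H]1CCCN(S(=O)(=O)c2ccc(S(=O)(=O)N3CC[C@@H](O)C3)cc2)C1)N1CCC(F)(F)CC1` gives > 3000 nM, and this too is a limit. Compound 1 therefore has no exact position on the scale. Compound 3 `CCN(CC)S(=O)(=O)c1ccc(S(=O)(=O)N2CCC[C@@H](C(=O)NC3CCOCC3)C2)cc1` keeps the core of compound 1 but has oxan-4-yl in place of 4-methoxycyclohexyl on an amide-type nitrogen. A six-membered non-aromatic ring of carbon only thus gives way to one with a hetero atom. Among the compounds with values here, no measured pair of compounds shows the effect of this change. The expectation therefore rests on compound 1, with its limit of > 10000 nM. The expected change, a number no higher from compound 1 to compound 3 (the limit leaves the size open), is no step beyond the usual scatter in this assay, in either direction. For compound 3, the estimated value is 10000 nM, with an expected range from 3000 nM to 30000 nM.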

Compound 3, half-maximal inhibitory concentration: > 10000 nM
Compound 3 ended at the assay's limit (the forecaster's own chance of this, stated with the estimate: 85%); the middle value lies on the limit itself.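

Compound 3 gives > 10000 nM, which is a limit and not a measured number. Compound 1 also stands at a limit, so no step can be read between compound 1 and compound 3. The compounds shown leave open whether oxan-4-yl in place of 4-methoxycyclohexyl changes inhibition at all.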